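Shifting the chlorine around the chlorobenzyl ring

This account rests on a few compounds, and the source may have more. Where it says the series, first, only, none or still open, it means among the compounds named here.

Compound 1 `COc1ccc(C2N=C(SCc3ccccc3)NC(C)=C2C(=O)Nc2ccc(Br)cc2)cc1` gives 11.3% in a functional assay on the whole organism (artery, strain albino) with Rattus norvegicus as the target, with a stated time of 600 min, at a dose of 10 mg/kg by the oral route; on this read-out lower numbers stand for less inhibition and higher numbers for more inhibition at the one dose given (going by the name of the read-out).
Compound 2 `COc1ccc(C2N=C(SCc3ccccc3Cl)NC(C)=C2C(=O)Nc2ccc(Br)cc2)cc1` gives 13.3%.
Compound 3 `COc1ccc(C2N=C(SCc3cccc(Cl)c3)NC(C)=C2C(=O)Nc2ccc(Br)cc2)cc1` gives 32.8%.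

Compound 3 stands highest of the three: a number 19.5 percentage points higher from compound 2 to compound 3 (beyond the scatter), and a number 21.5 percentage points higher from compound 1 to compound 3 (beyond the scatter). Compound 4 `COc1ccc(C2N=C(SCc3ccc(Cl)cc3)NC(C)=C2C(=O)Nc2ccc(Br)cc2)cc1` differs from compound 3 only in the position of the chlorine: 4-chlorophenyl in place of 3-chlorophenyl on a saturated chain carbon bound to a sulfur. The step that bears most on this is the earlier move of the same chlorine, a number 19.5 percentage points higher from compound 2 to compound 3 (beyond the scatter), while adding chlorine in the first place gave a number 2 percentage points higher from compound 1 to compound 2 (within the scatter) in one position and a number 21.5 percentage points higher from compound 1 to compound 3 (beyond the scatter) in another. Among the measured compounds shown here, one move of the chlorine thus mattered and one did not, and no measured pair covers the move to the 4-position. Compound 4 is therefore expected to stay roughly where compound 3 is, with a number 2.8 percentage points lower from compound 3 to compound 4 (within the scatter), and is estimated at 30%, between 12% and 48%.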

Compound 4, a percentage reported as inhibition, in the whole organism at one dose (the size of the read-out at that dose, not a potency): 30.3%
Compound 4: the middle estimate sits 0.3 percentage points below what was measured, within the range that was stated.
By their numbers in this assay, from the lowest: compounds 1 and 2 (each within the scatter of the next); then compounds 4 and 3 (each within the scatter of the next).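

In this assay the 4-chlorophenyl group on the saturated chain carbon bound to a sulfur performs much like the 3-chlorophenyl group, with a number 2.5 percentage points lower from compound 3 to compound 4 (within the scatter). The gain over the other two compounds remains, with a number 17 percentage points higher from compound 2 to compound 4 (beyond the scatter) and a number 19 percentage points higher from compound 1 to compound 4 (beyond the scatter), so only the 2-chlorophenyl group stays within the scatter of compound 1, which carries no chlorine on that ring. Nothing available explains this difference between the chlorine positions.

Still open, as far as these compounds go, is whether a nitrile or an amine in place of the chlorine would hold the same level.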